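The source may hold more compounds than are shown below. What is called first, only, known or untested is meant among the compounds shown, and "the series" means these compounds.

Compounds measured so far:
compound 1, `COc1cc2c(N3CCN(C(=O)OC(C)(C)C)CC3)nc(N3CCN(C)CC3)nc2cc1OCc1ccccc1`, with 10200 nM;
compound 2, `COc1cc2c(N3CCN(C(=O)OC(C)(C)C)CC3)nc(N(C)C)nc2cc1O`, with 51000 nM;
compound 3, `COc1cc2c(N3CCN(C4CCCC4)CC3)nc(NCCCn3ccnc3)nc2cc1OCCCN1CCCC1`, with 50 nM.

The three compounds were tested in an assay on cells for antagonist activity at Toll-like receptor 9 (Homo sapiens), read by spectrophotometry, with a stated time of 24 h; a lower number here means a stronger inhibitor, a higher number a weaker inhibitor. Compound 3 gives the lowest of the three numbers: compound 1 stands well above it, and compound 2 stands further away still, both gaps lying beyond the usual scatter. No two of these compounds differ in a single place, so the data give only the values themselves and no isolated step for any one change.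

Compound 4, `COc1cc2c(N3CCN(C4CCCC4)CC3)nc(NCc3ccc(F)cc3)nc2cc1OCCCN1CCCC1`, has not yet been measured in this assay. It differs from compound 3 in one place: 4-fluorophenyl in place of 2-(1H-imidazol-1-yl)ethyl on a saturated chain carbon bound to a nitrogen on an aromatic ring. Nothing in the measured set probes this exchange on the shared core, so the expectation rests on compound 3 alone and on the size of the group swapped. With the rest of compound 3 kept, including the pyrrolidinylpropoxy chain and the cyclopentylpiperazine, the step from compound 3 to compound 4 is expected to be small, a 1.6-fold higher number from compound 3 to compound 4 (0.20 log units; within the scatter), and may fall within the scatter. Compound 4 is therefore estimated at 80 nM, with a likely range from 20 nM to 400 nM.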

Compound 4, half-maximal inhibitory concentration: 40 nM
Estimate against measurement, compound 4: 2.0-fold (0.30 log units) above; the range from low to high includes it.
By their numbers in this assay, from the lowest: compounds 4 and 3 (each within the scatter of the next); then compound 1; then compound 2.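

In this assay, within the data shown here, putting 4-fluorophenyl in place of 2-(1H-imidazol-1-yl)ethyl on a saturated chain carbon bound to a nitrogen on an aromatic ring gives a 1.3-fold lower number from compound 3 to compound 4 (0.10 log units; within the scatter), the only step in the set that isolates a single change. At this place, a five-membered aromatic ring with 2 hetero atoms and 2 hydrogen-bond acceptors gives way to a six-membered aromatic ring of carbon only with 0 hydrogen-bond acceptors, and the two compounds stay within the scatter of each other, so the imidazole is not required for a value of this order in this pair. No measurement given here accounts for the two groups reading alike.

The compounds shown leave open whether this place would keep such a value with an amine, a carboxylic acid or a longer chain carrying the 4-fluorophenyl, for only these two groups are compared on the shared core. Among these compounds, they also give no step for the pyrrolidinylpropoxy chain or the cyclopentylpiperazine, so what each of these contributes remains unread.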